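The source may hold more compounds than are shown below. What is called first, only, known or untested is meant among the compounds shown, and "the series" means these compounds.

Series values in a functional assay on HL-60 cells (Homo sapiens) for antiproliferative activity, read by MTT assay, with a stated time of 72 h; on this read-out lower numbers stand for stronger inhibition and higher numbers for weaker inhibition:
- compound 1 `COc1cc(C(=O)c2sc3ccccc3c2-c2ccc(F)cc2)cc(OC)c1OC`: 3200 nM
- compound 2 `COc1cc(C(=O)c2sc3ccccc3c2-c2ccc(C)cc2)cc(OC)c1OC`: 1400 nM
- compound 3 `COc1ccc(-c2c(C(=O)c3cc(OC)c(OC)c(OC)c3)sc3ccccc23)c(OC)c1`: 4600 nM

Two steps place the 2,4-dimethoxyphenyl member, compound 3, in this small set: a 1.4-fold higher number from compound 1 to compound 3 (0.16 log units; within the scatter), and a 3.3-fold higher number from compound 2 to compound 3 (0.52 log units; beyond the scatter). It therefore sits level with compound 1 and apart from compound 2.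

Compound 4 `COc1ccc(-c2c(C(=O)c3cc(OC)c(OC)c(OC)c3)sc3ccccc23)cc1C` is still unmeasured in this assay. It carries 4-methoxy-3-methylphenyl in place of 2,4-dimethoxyphenyl on an aromatic carbon of the five-membered aromatic ring with 1 sulfur: 4-methoxy-3-methylphenyl in place of 2,4-dimethoxyphenyl on an aromatic carbon.

Within the data shown here, no measured step covers this exchange directly. The closest evidence is the change to 4-methylphenyl, which gave a 3.3-fold higher number from compound 2 to compound 3 (0.52 log units; beyond the scatter) when read in reverse, so the size of that gap is the best available guide. The methyl in place of fluoro step also points the same way: a 2.3-fold lower number from compound 1 to compound 2 (0.36 log units; beyond the scatter). Among the measured compounds shown here, both are modest, and the set holds only three compounds. The entering group also retains a methoxy, so the full gap to compound 2, at 1400 nM, need not be reached.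

The estimated step is modest and is expected to be a 2.3-fold lower number from compound 3 to compound 4 (0.36 log units; beyond the scatter). For compound 4 the estimated value is 2000 nM, with an expected range from 800 nM to 5000 nM.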

Compound 4, half-maximal inhibitory concentration: > 10000 nM
Compound 4 was reported as a limit; the forecaster's own chance of this, stated with the estimate: 5%; at least 5.0-fold (0.69 log units) between middle value and limit.
By their numbers in this assay, from the lowest: compound 2; then compounds 1 and 3 (each within the scatter of the next). At a limit, above all of these: compound 4.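

In this assay, among these compounds, compound 4 is reported only as a limit, the one such value in the set: the limit of > 10000 nM in this assay, at which 1 of the 4 values shown sits. Read against the three measured members, that limit gives an at least 2.1-fold higher number from compound 3 to compound 4 (0.33 log units; beyond the scatter), an at least 7.1-fold higher number from compound 2 to compound 4 (0.85 log units; beyond the scatter) and an at least 3.1-fold higher number from compound 1 to compound 4 (0.49 log units; beyond the scatter), so all three steps are beyond the scatter, though each gives only a minimum size. Until now, the aryl exchanges at this position spanned a modest range, with compounds 1 and 3 within the scatter of each other; 4-methoxy-3-methylphenyl now falls clearly outside that range, and its methyl group did not preserve the level of compound 2, which has 4-methylphenyl and reads 1400 nM.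

From the compounds shown here alone, the true size of these steps remains open, as does whether the change tracks the methoxy, the methyl or their combination in the entering group; 4-methoxyphenyl and 3-methylphenyl members would help to separate these. Going by these compounds, how an amine or a carboxylic acid on this aryl ring would read in this assay also remains open.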